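Replacing Hexyl by Cyclopentyl on the Shared Core

The source may report more compounds than this note shows. Statements on the series, on what has been measured and on what is new or still open speak of the compounds shown alone.

Of the compounds shown here, three have been measured so far in a functional assay on MIA PaCa-2 cells (Homo sapiens) for antiproliferative activity, read by MTT assay, with a stated time of 48 h; a higher number here means a weaker inhibitor, a lower number a stronger inhibitor. Compound 1 `Nc1nc(CC2CCCC2)c(-c2ccccc2Br)n1CC(=O)Nc1ccccc1` gives 61400 nM. Compound 2 `CCCCCCc1nc(N)n(CC(=O)Nc2ccc(C)cc2)c1-c1ccccc1Br` gives 6500 nM, and compound 3 `CCCCCCCc1nc(N)n(CC(=O)Nc2ccc(C)cc2)c1-c1ccccc1Br` gives 7000 nM. Among these three numbers compound 3 stands second highest; its nearest neighbour is compound 2, and the step of a 1.1-fold higher number from compound 2 to compound 3 (0.03 log units; within the scatter) lies within the scatter, while the gap to compound 1 is beyond it.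

Compound 4 `Cc1ccc(NC(=O)Cn2c(N)nc(CC3CCCC3)c2-c2ccccc2Br)cc1` has not yet been measured in this assay. The change from compound 3 to compound 4 is cyclopentyl in place of hexyl on a saturated chain carbon bound to an aromatic carbon. Among the measured compounds shown here, no measured step covers this change directly. For the measured compounds named here, the only measured single step, a 1.1-fold higher number from compound 2 to compound 3 (0.03 log units; within the scatter), lengthened the chain and left the number essentially unchanged. Compound 1, which carries the cyclopentylmethyl group but lacks the methyl on the anilide, shows a far higher number than compounds 2 and 3, yet it differs from them in two places, so that gap cannot be assigned to the ring alone.

The estimate for compound 4 is therefore a moderately higher number than compound 3, roughly a 2.1-fold higher number from compound 3 to compound 4 (0.33 log units; beyond the scatter), with wide uncertainty. Compound 4 is expected to give about 15000 nM, in the range 5000 nM to 50000 nM.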

Compound 4, half-maximal inhibitory concentration: 80500 nM
Compound 4: middle estimate off by 5.4-fold (0.73 log units), on the low side; the whole stated range lies below it.
By their numbers in this assay, from the lowest: compounds 2 and 3 (each within the scatter of the next); then compounds 1 and 4 (each within the scatter of the next).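

In this assay this place, a saturated chain carbon bound to an aromatic carbon, proves sensitive to what stands on it, although lengthening the open chain had moved nothing beyond the scatter. Cyclopentyl in place of hexyl gives a 12-fold higher number from compound 3 to compound 4 (1.06 log units; beyond the scatter) and cyclopentyl in place of pentyl gives a 12-fold higher number from compound 2 to compound 4 (1.09 log units; beyond the scatter) with all else shared, and both are large steps. Methyl in place of hydrogen on an aromatic carbon, by contrast, gives a 1.3-fold higher number from compound 1 to compound 4 (0.12 log units; within the scatter) and stays within the scatter, so the high number of compound 1 now reads as going with the cyclopentylmethyl group and not with the missing methyl.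

As far as these compounds go, whether a cyclobutyl or cyclohexyl group, or a branched chain such as isobutyl, would stay with the open chains or fall with compound 4 remains open, as does the effect of a shorter chain such as butyl. No measurement at hand accounts for the size of these steps.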